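This account rests on a few compounds, and the source may have more. Where it says the series, first, only, none or still open, it means among the compounds named here.

Three compounds of a shared core are described here, along with one that has not yet been tested. Compound 1 `O=C(Nc1cc(C(F)(F)F)ccc1N1CCCC1)c1cccnc1` carries a pyrrolidinyl group, and in a functional assay on NALM-6 cells (Homo sapiens) for cytotoxicity, read by MTT assay, with a stated time of 48 h (a higher number here means a weaker inhibitor, a lower number a stronger inhibitor), compound 1 gives "not active" (no number reported), with no number given. Compound 2 `O=C(Nc1cc(C(F)(F)F)ccc1Nc1ccc(Br)cc1)c1ccncc1` carries a bromophenylamino group, and in this assay compound 2 gives 51900 nM. Compound 3 `CCN(CC)c1ccc(C(F)(F)F)cc1NC(=O)c1cccnc1` carries a diethylamino group, and in this assay compound 3 gives 63200 nM. Among the two compounds with a number, compound 3 has the higher one, but the gap to compound 2 lies within the scatter of the method, so the two are not distinguished.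

Compound 4 `CCN(CC)c1ccc(C(F)(F)F)cc1NC(=O)c1ccncc1` is the untested compound. It differs from compound 3 in one place (pyridin-4-yl in place of pyridin-3-yl on a carbonyl carbon). Compound 2 shows that a pyridin-4-yl carbonyl on this core gives a weak result, so no step beyond the scatter is expected from compound 3 to compound 4, and the expected step is a 1.1-fold lower number from compound 3 to compound 4 (0.06 log units; within the scatter). Compound 4 is estimated to give 55000 nM, with a range from 25000 nM to 120000 nM.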

Compound 4, half-maximal inhibitory concentration: 63600 nM
Compound 4: the middle estimate sits 1.2-fold (0.06 log units) below what was measured; the range from low to high includes it.
By their numbers in this assay, from the lowest: compounds 2, 3 and 4 (each within the scatter of the next).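

With diethylamino on the shared core, pyridin-4-yl in place of pyridin-3-yl on a carbonyl carbon gives a 1.0-fold higher number from compound 3 to compound 4 (0.00 log units; within the scatter) in this assay and so leaves the two pyridine forms undistinguished at this position. With pyridin-4-yl held fixed, diethylamino in place of (4-bromophenyl)amino on an aromatic carbon gives a 1.2-fold higher number from compound 2 to compound 4 (0.09 log units; within the scatter) and likewise separates neither compound from the other in this read-out, although the two groups differ widely in structure. Nothing at hand explains either result.

The compounds shown leave open whether a pyridin-2-yl or a plain phenyl ring on the carbonyl carbon would stand apart from these values. They also leave open what a primary amine, a carboxylic acid or a longer alkyl chain would give in place of diethylamino on the aromatic carbon.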